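This account rests on a few compounds, and the source may have more. Where it says the series, first, only, none or still open, it means among the compounds named here.

- Compound 1 `CC/C(=C(/c1csc(/C=C/C(=O)O)c1)c1ccc2[nH]ncc2c1)c1ccccc1`, in a functional assay on MCF7 cells (Homo sapiens) for cytotoxicity, read by CellTiter-Glo, with a stated time of 5 days; a higher number here means a weaker inhibitor, a lower number a stronger inhibitor: 2900 nM
- Compound 2 `CC/C(=C(/c1ccc(/C=C/C(=O)O)cc1)c1ccc2[nH]ncc2c1)c1ccccc1Cl`, in this assay: 2 nM

Compound 2 holds the lower of these two numbers, making it the stronger inhibitor of the pair. Its nearest neighbour, compound 1, lies far beyond the scatter of repeated measurements. These two compounds differ in more than one place, however, so their gap cannot be tied to any single structural change.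

Compound 3 `CC/C(=C(/c1ccc(/C=C/C(=O)O)cc1)c1ccc2[nH]ncc2c1)c1ccccc1OC` has not yet been measured. It matches compound 2 except for one group: methoxy in place of chloro on an aromatic carbon, ortho to a large group (methoxy in place of chloro on an aromatic carbon). Within the data shown here, no measured pair shows this swap directly, so any forecast is uncertain. Compound 2 already sits very low at 2 nM, which leaves more room for the number to rise than to fall. A modest upward step in this assay is therefore expected, slightly beyond the scatter and far smaller than the gap between the two measured compounds. The estimate amounts to a 4.0-fold higher number from compound 2 to compound 3 (0.60 log units; beyond the scatter). The estimated value for compound 3 is 8 nM, expected to lie between 2 nM and 40 nM.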

Compound 3, half-maximal inhibitory concentration: 25 nM
Estimate against measurement, compound 3: 3.1-fold (0.49 log units) below; low and high end bracket the measured number.
By their numbers in this assay, from the lowest: compound 2; then compound 3; then compound 1.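

Among these compounds, compound 2 and compound 3 form the first pair here that differs in only one place, so this is the first step that can be read as a single change: a 13-fold higher number from compound 2 to compound 3 (1.10 log units; beyond the scatter) in this assay. It shows that this position, on an aromatic carbon ortho to a large group, is not indifferent to what sits there, since going from 2-chlorophenyl to 2-methoxyphenyl moves the number well beyond the scatter, with chloro on the lower side. Nothing measured here accounts for the size of this step, so the reason for it stays unknown.

As far as these compounds go, two groups at one position cannot establish a trend, so it remains open how fluoro, methyl or a bare hydrogen at the same place would compare with chloro and methoxy. From the compounds shown here alone, it is also open whether the swap from chloro to methoxy would give a step of similar size on the core of compound 1, or whether its size belongs to the core shared by compound 2 and compound 3.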